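The compounds below may be only part of what the source reports. "The series", "measured", "known", "first", "only" and "open" are said of these compounds alone.

Compound 1 `O=C(Nc1c(F)cc(F)cc1F)N(Cc1ccc(-c2cccs2)cc1)C1CCCCCC1` is tested in an assay on microsomes from intestine for inhibition of acyl-CoA:cholesterol acyltransferase (Oryctolagus cuniculus) (a higher number here means a weaker inhibitor, a lower number a stronger inhibitor), where compound 1 gives 18 nM. Two further compounds share its urea core. Compound 2 `Cc1cc(C)c(NC(=O)N(Cc2cccc(-c3cc[nH]n3)c2)C2CCCC2)c(C)c1` gives 22 nM in this assay, and compound 3 `Cc1cc(C)c(NC(=O)N(Cc2ccc(-c3cccs3)cc2)C2CCCCCC2)c(C)c1` gives 22 nM. Compound 1 holds the lowest of the three numbers, but its distance to compound 2 and to compound 3 lies within the scatter, so the three stand level. Among the compounds with values here, the single one-place step, a 1.2-fold higher number from compound 1 to compound 3 (0.09 log units; within the scatter), changes only the aryl group on the urea nitrogen and leaves the biaryl side untouched.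

Compound 4 `O=C(Nc1c(F)cc(F)cc1F)N(Cc1ccc(-c2ccccn2)cc1)C1CCCCCC1` differs from compound 1 at the other end of the molecule: pyridin-2-yl in place of thiophen-2-yl on an aromatic carbon. Within the data shown here, no measured step touches this position, so nothing here speaks directly to it. Compound 2 carries a five-membered ring with two nitrogens on its biaryl arm and sits within the scatter of compound 1, but it differs in several places at once, so only its value can be noted. Among the measured compounds shown here, since the one step seen is flat and the one variation of the biaryl ring seen is flat, compound 4 is expected to stay close to compound 1, with a 1.7-fold higher number from compound 1 to compound 4 (0.22 log units; within the scatter) foreseen as a step within the scatter. Compound 4 is therefore estimated at 30 nM, between 10 nM and 90 nM.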

Compound 4, half-maximal inhibitory concentration: 25 nM
Beside the measured number, compound 4's estimate is 1.2-fold (0.08 log units) above it; the range from low to high includes it.
By their numbers in this assay, from the lowest: compounds 1, 2, 3 and 4 (each within the scatter of the next).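

In this assay, the position on an aromatic carbon of the six-membered carbon ring, para to a large group, now has a direct reading: putting pyridin-2-yl in place of thiophen-2-yl gives a 1.4-fold higher number from compound 1 to compound 4 (0.14 log units; within the scatter). The earlier compounds shown here offered no one-place step here, and this one shows that a six-membered aromatic ring with a nitrogen can stand in for a five-membered aromatic ring with a sulfur without moving the number beyond the scatter, although ring size and hetero atom change together, so their separate contributions cannot be told apart. Nothing available accounts for why the number holds level across this change.

Both groups seen at this position are aromatic rings with one hetero atom and no hydrogen-bond donor, so the compounds shown do not say whether the position would stay as flat with a carboxylic acid, an amine or a longer chain in that place. They also leave open whether pyridin-3-yl, with its nitrogen placed differently in the ring, would stay level with compound 4.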